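A few compounds are considered here, and "the series" means these few. Any claim that something is new, unique, unknown or untested is made for them only; others in the source may bear on it.

Going by the values given here, in a functional assay on A549 cells (Homo sapiens) for antiproliferative activity, read by MTT assay (a lower number here means a stronger inhibitor, a higher number a weaker inhibitor), compound 2 `Cn1c(=O)c(=O)n(C2CCCC2)c2nc(N/N=C/c3ccc(Cl)cc3)ncc21` gives 6890 nM, the only outright number so far. Compound 1 `Cn1c(=O)c(=O)n(C2CCCC2)c2nc(N/N=C/c3ccc(O)cc3)ncc21` gives a limit in this assay, > 100000 nM. Among the compounds with values here, the one measured step is an at least 14-fold lower number from compound 1 to compound 2 (1.16 log units; beyond the scatter). Compound 3 `COc1cccc(/C=N/Nc2ncc3c(n2)n(C2CCCC2)c(=O)c(=O)n3C)c1` differs from compound 2 in a single place: 3-methoxyphenyl in place of 4-chlorophenyl on a carbon with a double bond to nitrogen. Within the data shown here, no measured step exchanges a chloro group for a methoxy group, so the step of an at least 14-fold lower number from compound 1 to compound 2 (1.16 log units; beyond the scatter) shows only that a change on that phenyl can shift the number far. A modest weakening is expected, a 1.7-fold higher number from compound 2 to compound 3 (0.24 log units; within the scatter). Compound 3 is therefore estimated at 12000 nM, between 3000 nM and 50000 nM.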

Compound 3, half-maximal inhibitory concentration: 27400 nM
Compound 3: the middle estimate sits 2.3-fold (0.36 log units) below what was measured, within the range that was stated.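

In this assay, the new group gives a middle result on this phenyl: 3-methoxyphenyl in place of 4-chlorophenyl costs activity, with a 4.0-fold higher number from compound 2 to compound 3 (0.60 log units; beyond the scatter), yet 3-methoxyphenyl in place of 4-hydroxyphenyl gains it, with an at least 3.6-fold lower number from compound 1 to compound 3 (0.56 log units; beyond the scatter). The three groups thus fall in an order, with 4-chlorophenyl ahead of 3-methoxyphenyl and 3-methoxyphenyl ahead of 4-hydroxyphenyl. Compound 1 stands at a limit, so the second step gives only a minimum size: the limit of > 100000 nM in this assay, at which 1 of the 3 values shown sits.

Both new steps change the group and its number on the ring together, and the compounds shown do not separate the two. Going by these compounds, how an amine or a carboxylic acid on this phenyl would fare also stays open.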